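The source may report more compounds than this note shows. Statements on the series, on what has been measured and on what is new or still open speak of the compounds shown alone.

Series notes. Compound 1 `O=C(C/C=C/c1cccc(Cl)c1)Nc1nc2ccccc2c(=O)s1` and compound 2 `O=C(CCc1ccccc1)Nc1nc2ccccc2c(=O)s1` share the same core and differ in the acyl chain. In an assay on CHO cells for displacement of a labelled ligand from adenosine receptor A3 (Homo sapiens), read by scintillation counting, with a stated time of 60 min (on this read-out higher numbers stand for weaker inhibition and lower numbers for stronger inhibition), compound 1 returns only a limit, > 1000 nM, and no number behind it. In this assay, going by the values given here, compound 2 gives 390 nM, the only actual number so far. The other entry, that of compound 1, is a limit, as noted at the limit of > 1000 nM in this assay, at which 1 of the 2 values shown sits. Among the compounds with values here, compound 2 is therefore the sole fixed point for comparison. Compound 3 `O=C(CCc1ccccc1Br)Nc1nc2ccccc2c(=O)s1` has not yet been measured. It differs from compound 2 by bromo in place of hydrogen on an aromatic carbon; the bromine enters on an aromatic carbon of a six-membered aromatic ring of carbon only, ortho to a large group. Within the data shown here, no measured pair of this kind exists in the set, so no step size can be read from the data. The step is expected to stay within the usual scatter: a 1.0-fold higher number from compound 2 to compound 3 (0.01 log units; within the scatter). Compound 3 is estimated at 400 nM, with a range from 150 nM to 1500 nM.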

Compound 3, inhibition constant: > 1000 nM
Compound 3: only a limit was reported (the forecaster's own chance of this, stated with the estimate: 25%); at least 2.5-fold (0.39 log units) between middle value and limit.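

Bromo in place of hydrogen on an aromatic carbon, ortho to a large group, gives the first step in the series that can be read against a fixed number: in this assay the change gives an at least 2.5-fold higher number from compound 2 to compound 3 (0.40 log units; beyond the scatter). The entry for compound 3, > 1000 nM, is a limit and not a number. This position on the ring is therefore not indifferent to substitution, and compound 2 remains the only compound with a number, the others sitting at the same limit: the limit of > 1000 nM in this assay, at which 2 of the 3 values shown sit.

How far the true value lies behind that limit cannot be read from the compounds shown. Also open, from the compounds shown here alone, is whether a smaller fluoro or a methyl at this same place would keep a number, or whether any replacement of this hydrogen ends at the limit.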